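A few compounds are considered here, and "the series" means these few. Any claim that something is new, unique, unknown or untested is made for them only; others in the source may bear on it.

Compound 1 `CN(Cc1ccccc1)C(=S)SCC1=CC(=O)OC1`: > 50 ug/mL.
Compound 2 `O=C1CC2(CO1)CSC(=S)N2c1ccc(F)cc1`: > 50 ug/mL.
Compound 3 `CN1CCN(C(=S)SCC2=CC(=O)OC2)CC1`: > 50 ug/mL.

In a functional assay on HeLa cells (Homo sapiens) for antiproliferative activity, read by MTT assay, with a stated time of 72 h (on this read-out lower numbers stand for stronger inhibition and higher numbers for weaker inhibition), compound 1 reaches only a limit of the assay, > 50 ug/mL. Compound 2 likewise stops at a limit, > 50 ug/mL. Compound 3 too returns a limit, > 50 ug/mL. Among the compounds with values here, all three values share (the limit of > 50 ug/mL in this assay, at which 3 of the 3 values shown sit), so none of the measured compounds is set apart from the others on this read-out. Compound 4 `CN(C)C(=S)SCC1=CC(=O)OC1` differs from compound 1 by hydrogen in place of phenyl on a saturated chain carbon bound to an amide-type nitrogen. Within the data shown here, no measured pair shows a change of this kind, so these numbers give no ground for a shift in either direction in this assay; the expected step is none beyond the scatter. Compound 4 is therefore estimated at 50 ug/mL, within a range from 20 ug/mL to 100 ug/mL. The expected step is a number no higher from compound 1 to compound 4 (the limit leaves the size open).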

Compound 4, half-maximal inhibitory concentration: > 50 ug/mL
Compound 4 was reported as a limit; the forecaster's own chance of this, stated with the estimate: 75%; the middle value sits exactly at the limit.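

Within the data shown here, compound 4, like compound 1, stops at a limit, so no step between them can be read in this assay: the limit of > 50 ug/mL in this assay, at which 4 of the 4 values shown sit. The compounds shown leave open whether hydrogen in place of phenyl changes the read-out at all.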